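Swapping 4-Methoxyphenyl for Pyridin-4-yl on the Shared Core

A few compounds are considered here, and "the series" means these few. Any claim that something is new, unique, unknown or untested is made for them only; others in the source may bear on it.

Compound 1 `CC(C)(C)n1cc2c(n1)C(=O)CC1(CCN(C(=O)c3cc(-c4ccccc4)nc4ccccc34)CC1)O2`: 1940 nM
Compound 2 `CC(C)(C)n1cc2c(n1)C(=O)CC1(CCN(C(=O)c3cc(-c4ccc(Br)cc4)nc4ccccc34)CC1)O2`: 9300 nM
Compound 3 `COc1ccc(-c2cc(C(=O)N3CCC4(CC3)CC(=O)c3nn(C(C)(C)C)cc3O4)c3ccccc3n2)cc1`: 3740 nM

In a functional assay on A549 cells (Homo sapiens) for inhibition, read by MTT assay, with a stated time of 72 h (on this read-out lower numbers stand for stronger inhibition and higher numbers for weaker inhibition), compound 3 gives 3740 nM. It sits close to one neighbour, with a 1.9-fold higher number from compound 1 to compound 3 (0.29 log units; within the scatter), and apart from the other, with a 2.5-fold lower number from compound 2 to compound 3 (0.40 log units; beyond the scatter). The next compound, compound 4 `CC(C)(C)n1cc2c(n1)C(=O)CC1(CCN(C(=O)c3cc(-c4ccncc4)nc4ccccc34)CC1)O2`, carries pyridin-4-yl in place of 4-methoxyphenyl on an aromatic carbon next to the ring nitrogen (pyridin-4-yl in place of 4-methoxyphenyl on an aromatic carbon). The measured steps that bear on this change all alter the same aryl group: a 4.8-fold higher number from compound 1 to compound 2 (0.68 log units; beyond the scatter) is modest, and a 1.9-fold higher number from compound 1 to compound 3 (0.29 log units; within the scatter) stays small. Within the data shown here, none of them places a nitrogen in that ring, so the data offer no direct precedent for this exchange. The measured changes at this place are no more than modest, so no step beyond the scatter is expected in this assay, though the uncertainty is wide. The expected change is a 1.1-fold lower number from compound 3 to compound 4 (0.03 log units; within the scatter). Compound 4 is estimated at 3500 nM, with an expected range from 1300 nM to 10000 nM.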

Compound 4, half-maximal inhibitory concentration: 550 nM
Beside the measured number, compound 4's estimate is 6.4-fold (0.80 log units) above it, and the stated range ends above it.
By their numbers in this assay, from the lowest: compound 4; then compounds 1 and 3 (each within the scatter of the next); then compound 2.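

In this assay, among these compounds, pyridin-4-yl is the first group at this position to give a lower number than the phenyl of compound 1, a 3.5-fold lower number from compound 1 to compound 4 (0.55 log units; beyond the scatter). It also stands clear of the other two aryl groups, a 6.8-fold lower number from compound 3 to compound 4 (0.83 log units; beyond the scatter) and a 17-fold lower number from compound 2 to compound 4 (1.23 log units; beyond the scatter), which makes compound 4 the strongest of the four shown. Among the compounds shown here, the earlier changes only added a group to the phenyl ring, and the one step among them beyond the scatter went the other way, a 4.8-fold higher number from compound 1 to compound 2 (0.68 log units; beyond the scatter), so a carbon-only ring bearing a substituent and a ring with one nitrogen clearly differ here, though no measurement offers an explanation for that difference.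

As far as these compounds go, it remains open whether pyridin-3-yl or pyridin-2-yl would match pyridin-4-yl here. From the compounds shown here alone, it is also open whether an amine or a methyl group on the pyridine ring would keep the lower number.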